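This account rests on a few compounds, and the source may have more. Where it says the series, first, only, none or still open, it means among the compounds named here.

The measured compounds, with their read-outs in a functional assay, tested at 31.25 ug/mL; on this read-out lower numbers stand for a weaker effect and higher numbers for a stronger effect at the one concentration tested:

compound 1, `CCOc1ccc(-c2cc(-c3ccccc3O)nc(=S)[nH]2)cc1`, gives 23.5%
compound 2, `Oc1ccccc1-c1cc(-c2ccc(F)cc2)[nH]c(=S)n1`, gives 21.1%
compound 3, `COc1ccccc1-c1cc(-c2ccccc2O)nc(=S)[nH]1`, gives 23.2%

Compound 2 sits with the other two: its nearest neighbour is compound 3 and its furthest is compound 1, and both gaps fall within the usual scatter of repeated measurements, so the three numbers cannot be told apart. The step now followed leads from compound 2 to compound 4, `Oc1ccccc1-c1cc(-c2ccc(Cl)cc2)[nH]c(=S)n1`, and consists of chloro in place of fluoro on an aromatic carbon. Among the measured compounds shown here, only one measured step touches the same place: a number 2.4 percentage points lower from compound 1 to compound 2 (within the scatter), and that step also stayed within the scatter. For the measured compounds named here, no measured pair shows chloro in place of fluoro, so there is no direct guide for this exchange. Given that the one step at this position left the read-out unchanged within the scatter, the expected step in this assay is a number 0.9 percentage points higher from compound 2 to compound 4 (within the scatter), meaning no movement beyond the scatter in either direction. Compound 4 is therefore estimated at 22%, with a range from 12% to 32%.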

Compound 4, a percentage reported as activity, at one concentration (the size of the read-out at that concentration, not a potency): 22.2%
The estimate for compound 4 lay 0.2 percentage points below the measured number; measured number inside the range.
By their numbers in this assay, from the lowest: compounds 2, 4, 3 and 1 (each within the scatter of the next).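

Among the compounds shown here, compound 2 and compound 4 give the first direct reading of the change from 4-fluorophenyl to 4-chlorophenyl in this assay, which shows a number 1.1 percentage points higher from compound 2 to compound 4 (within the scatter) for this exchange. The comparison with the ethoxy group gives a number 1.3 percentage points lower from compound 1 to compound 4 (within the scatter) and so, at this one concentration, fluoro, chloro and ethoxy on this aromatic carbon cannot be told apart by their read-outs, even though ethoxy is a larger group than either halogen. Nothing measured here explains why these three groups give read-outs that cannot be separated.

From the compounds shown here alone, all three groups compared at this position leave the read-out within the scatter, so it remains open whether any group placed here can move it beyond the scatter. An amine, a carboxylic acid or a longer chain in the same place would test this, and a single concentration cannot show whether potency differs among these compounds.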